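Cyano in place of hydrogen on compound 2

A few compounds are considered here, and "the series" means these few. Any claim that something is new, unique, unknown or untested is made for them only; others in the source may bear on it.

Compound 2 `CCN(Cc1cccs1)C(=O)COc1ccccc1` gives 1400 nM in an assay on HEK293 cells for agonist activity at transient receptor potential cation channel subfamily M member 8 (Homo sapiens), read by fluorescence and calcium flux, with a stated time of 15 min (on this read-out higher numbers stand for an effect only at larger amounts of compound and lower numbers for an effect already at smaller amounts), the highest of the three numbers measured. Compound 1 `CCN(Cc1cccs1)C(=O)COc1ccc(C(F)(F)F)cc1` gives 236 nM, and compound 3 `CCN(Cc1cccs1)C(=O)COc1cccc(C)c1` gives 97 nM. Compound 4 `CCN(Cc1cccs1)C(=O)COc1ccc(C#N)cc1` differs from compound 2 by cyano in place of hydrogen on an aromatic carbon. Among the measured compounds shown here, two measured steps bear on this change. The step of a 5.9-fold higher number from compound 1 to compound 2 (0.77 log units; beyond the scatter) shows that losing a group at the same place, para to a large group, raises the number. The step of a 14-fold lower number from compound 2 to compound 3 (1.16 log units; beyond the scatter) shows that adding a different substituent to the same ring lowers it. Both point toward a lower number once a substituent returns to this ring. A downward step beyond the scatter is therefore expected, a 3.1-fold lower number from compound 2 to compound 4 (0.49 log units; beyond the scatter). Compound 4 is expected at 450 nM, within 130 nM to 1600 nM.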

Compound 4, half-maximal effective concentration: 1990 nM
For compound 4 the middle estimate is 4.4-fold (0.65 log units) below the measured one; measured number above the stated range.
By their numbers in this assay, from the lowest: compound 3; then compound 1; then compounds 2 and 4 (each within the scatter of the next).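

In this assay, cyano at this place, para to a large group, gives a 1.4-fold higher number from compound 2 to compound 4 (0.15 log units; within the scatter) and so does not separate from hydrogen, which means that a substituent here does not by itself lower the number. Exchanging trifluoromethyl at the same place gives an 8.4-fold higher number from compound 1 to compound 4 (0.93 log units; beyond the scatter) and ties the lower number of compound 1 to that particular group rather than to substitution in general. Nothing available accounts for the difference between these two groups. As far as these compounds go, how an amine or a carboxylic acid at this place would compare with cyano and trifluoromethyl remains open.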